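Chalcone ether series: effect of a nitro group

The source may report more compounds than this note shows. Statements on the series, on what has been measured and on what is new or still open speak of the compounds shown alone.

Measured compounds:
Compound 1, `O=C(COc1ccc(C(=O)/C=C/c2ccc(F)cc2)cc1)N[C@H]1CCOC1=O`: 15600 nM
Compound 2, `O=C(COc1ccc(C(=O)/C=C/c2ccccc2)cc1)N[C@H]1CCOC1=O`: 56800 nM

Within the data shown here, in a functional assay on PC-3 cells (Homo sapiens) for antiproliferative activity, read by MTT assay, with a stated time of 72 h (on this read-out higher numbers stand for weaker inhibition and lower numbers for stronger inhibition), compound 2 gives 56800 nM, the highest of the two numbers so far; its nearest neighbour is compound 1, which in this assay gives 15600 nM. Among the measured compounds shown here, the one measured step, a 3.6-fold higher number from compound 1 to compound 2 (0.56 log units; beyond the scatter), shows that removing the fluoro from the aromatic carbon raises the number, so the unsubstituted ring of compound 2 is the weaker end of what is known.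

Compound 3, `O=C(COc1ccc(C(=O)/C=C/c2cccc([N+](=O)[O-])c2)cc1)N[C@H]1CCOC1=O`, differs from compound 2 by nitro in place of hydrogen on an aromatic carbon: a nitro group, with its two hydrogen-bond acceptors and no ring, enters on the six-membered aromatic ring of carbon only, meta to a large group. For the measured compounds named here, no measured step introduces a nitro group, and none places a substituent at this position, so the step from compound 1 to compound 2 bears on it only loosely: a substituent on this ring went with a lower number once. A step of similar size, towards a lower number, is therefore expected, a 2.8-fold lower number from compound 2 to compound 3 (0.45 log units; beyond the scatter), with wide uncertainty. Compound 3 is estimated at 20000 nM in this assay, in the range 5000 nM to 80000 nM.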

Compound 3, half-maximal inhibitory concentration: 56300 nM
Compound 3: the middle estimate sits 2.8-fold (0.45 log units) below what was measured, within the range that was stated.
By their numbers in this assay, from the lowest: compound 1; then compounds 3 and 2 (each within the scatter of the next).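

In this assay the nitro step, a 1.0-fold lower number from compound 2 to compound 3 (0.00 log units; within the scatter), leaves compound 3 indistinguishable from compound 2, so a nitro group on the six-membered aromatic ring, meta to a large group, gives no separation from the unsubstituted phenyl. The earlier link between a substituent on this ring and a lower number rested on fluoro alone, and compound 3 now goes against it: carrying a substituent on this ring is not enough. The comparison with the fluoro compound, a 3.6-fold higher number from compound 1 to compound 3 (0.56 log units; beyond the scatter), leaves compound 1 apart from both other compounds, but that step exchanges the group and its place together and cannot separate the two.

Still open, from the compounds shown here alone, is whether the group or its place sets this gap: nitro in the place fluoro holds in compound 1, fluoro in the place nitro holds in compound 3, or an amine or a methoxy group on this ring would each bear on that. No measurement at hand accounts for what the nitro group does at this position.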